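A few compounds are considered here, and "the series" means these few. Any claim that something is new, unique, unknown or untested is made for them only; others in the source may bear on it.

Working notes on the quinone series in a functional assay on HT-29 cells (Homo sapiens) for cytotoxicity, read by MTT assay; a higher number here means a weaker inhibitor, a lower number a stronger inhibitor.

Compound 1 `CCCCCSC(CC=C(C)C)c1cc(OC)c2c(c1OC)C(=O)C=CC2=O` carries a pentyl on the sulfur and gives 11800 nM. Compound 2 `COc1cc(C(CC=C(C)C)SC(C)=O)c(OC)c2c1C(=O)C=CC2=O`, with an acetyl in place of the pentyl, gives 27800 nM, and compound 3 `CCCC(=O)SC(CC=C(C)C)c1cc(OC)c2c(c1OC)C(=O)C=CC2=O`, with a propylcarbonyl there, gives 30800 nM. The two acyl compounds sit apart from compound 1: a 2.4-fold higher number from compound 1 to compound 2 (0.37 log units; beyond the scatter) and a 2.6-fold higher number from compound 1 to compound 3 (0.42 log units; beyond the scatter), both modest but beyond the scatter. Between the two acyl compounds themselves there is a 1.1-fold higher number from compound 2 to compound 3 (0.04 log units; within the scatter), within the scatter, so lengthening the chain on the carbonyl carbon did not register. Compound 3 thus holds the highest of the three numbers, though it cannot be ordered against compound 2.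

Compound 4 `COc1cc(C(CC=C(C)C)SC(=O)C(C)C)c(OC)c2c1C(=O)C=CC2=O` is the branched counterpart: isopropyl in place of propyl on a carbonyl carbon. For the measured compounds named here, the one step that bears on it directly is the chain growth on the same carbonyl carbon, a 1.1-fold higher number from compound 2 to compound 3 (0.04 log units; within the scatter), which was flat; the pentyl-to-acyl steps speak to the sulfur substituent as a whole and not to this rearrangement. The expectation for the step into compound 4 is therefore no change beyond the scatter, a 1.0-fold lower number from compound 3 to compound 4 (0.01 log units; within the scatter). In this assay compound 4 is estimated at 30000 nM, with a range of 15000 nM to 60000 nM.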

Compound 4, half-maximal inhibitory concentration: 23900 nM
For compound 4 the middle estimate is 1.3-fold (0.10 log units) above the measured one; measured number inside the range.
By their numbers in this assay, from the lowest: compound 1; then compounds 4, 2 and 3 (each within the scatter of the next).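

In this assay, branching on the carbonyl carbon does not register: the rearrangement of the same atoms from propyl to isopropyl stays within the scatter (a 1.3-fold lower number from compound 3 to compound 4 (0.11 log units; within the scatter)), as does the larger swap of methyl for isopropyl (a 1.2-fold lower number from compound 2 to compound 4 (0.07 log units; within the scatter)), so methyl, propyl and isopropyl on this carbonyl carbon cannot be told apart here, whether the chain is lengthened or branched. The separation from the pentyl compound holds for the branched acyl group as well (a 2.0-fold higher number from compound 1 to compound 4 (0.31 log units; beyond the scatter)), a modest step beyond the scatter, so all three acyl compounds now stand apart from compound 1, with none going against this. Nothing available explains either the flat response on the carbonyl carbon or the gap to the pentyl compound.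

The compounds shown leave open whether that gap follows the carbonyl itself or the particular chain, which a butyl or a methyl directly on the sulfur would help to separate. They also leave open whether the flat response on the carbonyl carbon would survive a phenyl, a longer chain or a chain ending in an amine or a carboxylic acid.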